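Ethyl in Place of Vinyl on a Shared Core

A few compounds are considered here, and "the series" means these few. Any claim that something is new, unique, unknown or untested is made for them only; others in the source may bear on it.

Compound 3 `C=Cc1ccsc1CN[C@@H]1C[C@H]2C[C@@H]([C@H]1C)C2(C)C` carries a vinyl group on an aromatic carbon of the shared core. In an ADME assay on MDCK cells (Canis lupus familiaris) for cytotoxicity, read by microscopy, with a stated time of 48 h (on this read-out higher numbers stand for lower toxicity in this test and lower numbers for higher toxicity in this test), compound 3 gives 50000 nM, level with compound 1 `CCCc1ccsc1CN[C@@H]1C[C@H]2C[C@@H]([C@H]1C)C2(C)C`, which gives 50000 nM; together these are the highest of the three numbers. Compound 2 `C[C@H]1[C@H](NCc2sccc2C2CCCCC2)C[C@H]2C[C@@H]1C2(C)C` gives 1560 nM, and a 32-fold higher number from compound 2 to compound 3 (1.51 log units; beyond the scatter) marks that gap. Compound 4 `CCc1ccsc1CN[C@@H]1C[C@H]2C[C@@H]([C@H]1C)C2(C)C` differs from compound 3 by ethyl in place of vinyl on an aromatic carbon. The step that bears on this is no change at the digits printed from compound 1 to compound 3 (within the scatter), where propyl and vinyl were indistinguishable; only the cyclohexyl of compound 2, seen in a 32-fold lower number from compound 1 to compound 2 (1.51 log units; beyond the scatter), moved the number. Since ethyl is neither a ring nor larger than propyl, the step to compound 4 is expected to stay within the scatter, no change at the digits printed from compound 3 to compound 4 (within the scatter). Compound 4 is estimated at 50000 nM, ranging from 25000 nM to 100000 nM.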

Compound 4, minimum cytotoxic concentration: 25000 nM
For compound 4 the middle estimate is 2.0-fold (0.30 log units) above the measured one; measured number inside the range.
By their numbers in this assay, from the lowest: compound 2; then compounds 4, 1 and 3 (each within the scatter of the next).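

In this assay, losing the double bond of the vinyl group at this aromatic carbon leaves the read-out within the scatter, with a 2.0-fold lower number from compound 3 to compound 4 (0.30 log units; within the scatter) as the step. Shortening propyl to ethyl behaves the same way, with a 2.0-fold lower number from compound 1 to compound 4 (0.30 log units; within the scatter) as the step. The larger step stays with the ring, since a 16-fold higher number from compound 2 to compound 4 (1.20 log units; beyond the scatter) is beyond the scatter, so vinyl, ethyl and propyl read alike while the cyclohexyl of compound 2 stands apart.

Nothing available here explains why the cyclohexyl group stands apart. Going by these compounds, what a phenyl ring, an amine or a carboxylic acid would give at this aromatic carbon remains open.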